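The source may report more compounds than this note shows. Statements on the series, on what has been measured and on what is new or still open speak of the compounds shown alone.

Series so far, in a functional assay on KM12 cells (Homo sapiens) for inhibition, read by sulforhodamine B assay, with a stated time of 48 h; on this read-out higher numbers stand for weaker inhibition of growth and lower numbers for stronger inhibition of growth:
compound 1 `Cc1ccc(C2=NN(c3ccc(S(C)(=O)=O)cc3)C(=O)CC2)cc1`: 440 nM
compound 2 `Cc1cc(O)ccc1C1=NN(c2ccc(S(C)(=O)=O)cc2)C(=O)CC1`: 4220 nM

Compound 2 has the higher of the two numbers, 4220 nM, and so the weaker growth inhibition. Next is compound 3 `CCc1ccc(C2=NN(c3ccc(S(C)(=O)=O)cc3)C(=O)CC2)cc1`, reached through (4-ethylphenyl in place of 4-hydroxy-2-methylphenyl on a carbon with a double bond to nitrogen). For the measured compounds named here, only one measured step bears on this change: a 9.6-fold higher number from compound 1 to compound 2 (0.98 log units; beyond the scatter), a modest step that introduced the 4-hydroxy-2-methylphenyl group, which now leaves. As far as these compounds go, a step of similar size toward a lower number is therefore expected in this assay, although 4-ethylphenyl itself is untested. The estimated change is a 7.0-fold lower number from compound 2 to compound 3 (0.85 log units; beyond the scatter). For compound 3 the expected value is 600 nM, with an estimated range of 200 nM to 1800 nM.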

Compound 3, concentration for 50% growth inhibition: 930 nM
For compound 3 the middle estimate is 1.6-fold (0.19 log units) below the measured one; the range from low to high includes it.
By their numbers in this assay, from the lowest: compound 1; then compound 3; then compound 2.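

In this assay, the 4-ethylphenyl group gives a 4.5-fold lower number from compound 2 to compound 3 (0.66 log units; beyond the scatter) and so recovers much of the difference seen with 4-hydroxy-2-methylphenyl, though not all of it. This position also distinguishes two close alkyl groups: the added methyl gives a 2.1-fold higher number from compound 1 to compound 3 (0.33 log units; beyond the scatter) and lies only just beyond the scatter. Nothing available explains either step.

The separate contributions of the hydroxyl and the 2-methyl in compound 2 remain unresolved. As far as these compounds go, it also remains open whether a longer chain such as propyl, or an amine on the same aromatic ring, would continue this trend.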